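The source may report more compounds than this note shows. Statements on the series, on what has been measured and on what is new or still open speak of the compounds shown alone.

Compound 1 `CCC1(Cc2ccccc2)OS(=O)(=O)C=C1OCc1ccc(OC)cc1` is measured in an ADME assay on HEL cells (Homo sapiens) for cytotoxicity, with a stated time of 3 days; a lower number here means that less compound is tolerated, a higher number that more compound is tolerated. There compound 1 reaches only a limit, >= 200000 nM.
Compound 2 `CCC1(Cc2ccccc2)OS(=O)(=O)C=C1OCc1ccccc1Cl` likewise reaches only a limit in this assay, >= 20000 nM.
Compound 3 `CCC1(Cc2ccccc2)OS(=O)(=O)C=C1OCCc1ccccc1` also reaches only a limit in this assay, >= 20000 nM.

Compound 2 therefore stands at a limit, the one at which two of the three values sit (the limit of >= 20000 nM in this assay, at which 2 of the 3 values shown sit), while one value sits at the higher limit (the limit of >= 200000 nM in this assay, at which 1 of the 3 values shown sits). Compound 4 `CCC1(Cc2ccccc2)OS(=O)(=O)C=C1OCc1ccccc1` differs from compound 2 by hydrogen in place of chloro on an aromatic carbon. The measured steps that bear on this change are a step that the two limits leave unreadable from compound 1 to compound 2 and a step that the two limits leave unreadable from compound 2 to compound 3; neither can be sized. No readable step is therefore expected in this assay, and compound 4 is expected to sit at a limit again, a number no higher from compound 2 to compound 4 (the limit leaves the size open). Compound 4 is estimated at 20000 nM, within 10000 nM to 200000 nM.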

Compound 4, minimum cytotoxic concentration: >= 50000 nM
Compound 4 ended at the assay's limit; the forecaster's own chance of this, stated with the estimate: 85%; middle value at least 2.5-fold (0.39 log units) away from the limit.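

Compound 4, like compound 1, compound 2 and compound 3, reaches only a limit in this assay, so none of its steps to them can be read. The compounds shown leave open whether hydrogen in place of chloro changes the minimum cytotoxic concentration at all.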